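The source may report more compounds than this note shows. Statements on the series, on what has been measured and on what is new or still open speak of the compounds shown alone.

Compound 1, `CC(C)CCn1nc(-c2cccs2)c(O)c(C2=NS(=O)(=O)c3cc(N(C)S(C)(=O)=O)ccc3N2)c1=O`: in a physicochemical assay for solubility, at pH 7.4 (on this read-out higher numbers stand for higher solubility and lower numbers for lower solubility), compound 1 gives > 100000 nM, which is a limit of the assay and not a number.
Compound 2, `CC(C)(C)Cc1nn(CCC2CC2)c(=O)c(C2=NS(=O)(=O)c3cc(NS(C)(=O)=O)ccc3N2)c1O`: in this assay compound 2 gives > 100000 nM, again a limit of the assay.
Compound 3, `CS(=O)(=O)Nc1ccc2c(c1)S(=O)(=O)N=C(c1c(O)c(C3=CCCC3)nn(CCC3CC3)c1=O)N2`: in this assay compound 3 gives > 100000 nM, also a limit of the assay.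

Compound 2 therefore stands only at a limit in this assay, and it is not alone there: the limit of > 100000 nM in this assay, at which 3 of the 3 values shown sit. For the measured compounds named here, the one measured step between two compounds that differ in a single place, a step that the two limits leave unreadable from compound 2 to compound 3, is thus unreadable in size, since both ends sit at the same limit.

Compound 4, `CC(C)CCn1nc(CC(C)(C)C)c(O)c(C2=NS(=O)(=O)c3cc(NS(C)(=O)=O)ccc3N2)c1=O`, differs from compound 2 in one place: isopropyl in place of cyclopropyl on a saturated chain carbon, two bonds along the chain from an aromatic nitrogen. No measured step touches this particular change, and the only step shown gives no readable size at all. Going by the values given here, what the three measurements do show is that every compound so far has stayed at the limit, so compound 4 is expected to do the same, and the step from compound 2 to compound 4 is estimated as a step that the limit leaves unreadable from compound 2 to compound 4, nothing that would pull the value back into the readable range. Compound 4 is therefore expected to give 150000 nM in this assay, within a range from 60000 nM to 400000 nM, and most likely to be reported once more as a limit rather than a number.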

Compound 4, solubility: > 100000 nM
Compound 4: no number, only a limit; the forecaster's own chance of this, stated with the estimate: 80%; the middle value is on the limit's open side.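

For the compounds shown here, compound 2 and compound 4 both stand at a limit in this assay, so no step between them can be read. The compounds shown leave open what number any of them would give, and whether any change to them would bring a value into the readable range: the limit of > 100000 nM in this assay, at which 4 of the 4 values shown sit.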